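Swapping Methoxy for Methyl: Compound 1 to Compound 4

The source may hold more compounds than are shown below. What is called first, only, known or untested is meant among the compounds shown, and "the series" means these compounds.

Three amides built on one shared core have been measured for lipophilicity. Compound 1 `CNC(=O)c1cc(C(=O)NC2CC2)cn(Cc2cccc(OC)c2)c1=O` gives 3 in a physicochemical assay for lipophilicity, at pH 7.4 (on this read-out lower numbers stand for lower lipophilicity and higher numbers for higher lipophilicity), the second highest of the three numbers. Compound 3 `CNC(=O)c1cc(C(=O)NCCOC)cn(Cc2ccccc2)c1=O` gives 2.7, which sits within the usual scatter of the number for compound 1. Compound 2 `CNC(=O)c1cc(C(=O)NCC(C)C)cn(Cc2ccccc2)c1=O` gives 4.3, the highest of the three and beyond the scatter from compound 1. Among the measured compounds shown here, the only single-point step measured so far is a number 1.60 log units lower from compound 2 to compound 3 (beyond the scatter), a large fall when methoxymethyl took the place of isopropyl on a saturated chain carbon bound to an amide-type nitrogen.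

Compound 4 `CNC(=O)c1cc(C(=O)NC2CC2)cn(Cc2cccc(C)c2)c1=O` differs from compound 1 by methyl in place of methoxy on an aromatic carbon. For the measured compounds named here, no measured step alters the aromatic ring, so the step from compound 2 to compound 3 bears on this change only indirectly: there a group carrying an ether oxygen entered and the number fell sharply, whereas here the methoxy, with its one oxygen, leaves and a methyl enters. A rise in this assay is therefore expected, smaller than that earlier step. Compound 4 is estimated at 3.4, within 3 to 3.8, the expected step being a number 0.40 log units higher from compound 1 to compound 4 (beyond the scatter).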

Compound 4, distribution coefficient: 3.6
For compound 4 the middle estimate is 0.20 log units below the measured one; the measured number falls inside the stated range.
By their numbers in this assay, from the lowest: compounds 3 and 1 (each within the scatter of the next); then compound 4; then compound 2.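

Among the compounds shown here, the exchange of methoxy for methyl gave a number 0.60 log units higher from compound 1 to compound 4 (beyond the scatter) in this assay, the first measured step on the aromatic ring of this series. It shows that the read-out responds to the 3-methoxyphenyl to 3-methylphenyl change at this aromatic carbon, meta to a large group, and that a change here, and not only on the amide chain, can move the number beyond the scatter. This modest step runs upward and is smaller than a number 1.60 log units lower from compound 2 to compound 3 (beyond the scatter) on a saturated chain carbon, but no information is available on what lies behind it, and this one pair does not separate the loss of the oxygen from any other part of the exchange.

The compounds shown leave open where other groups at this aromatic carbon, such as a chlorine, a nitrile, an amine or a carboxylic acid, would fall relative to methoxy and methyl. For the compounds shown here, they also leave open whether the same exchange gives a step of similar size when the amide chain of compound 1 is replaced by the one carried by compound 2 or compound 3.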